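This account rests on a few compounds, and the source may have more. Where it says the series, first, only, none or still open, it means among the compounds named here.

Working notes on the series. In a functional assay on HCT-116 cells (Homo sapiens) for inhibition, read by MTT assay, with a stated time of 72 h (a higher number here means a weaker inhibitor, a lower number a stronger inhibitor), compound 1 (`COc1cc2c(Oc3ccc(NC(=O)c4nn(-c5ccccc5C)cc(C)c4=O)c(F)c3)ccnc2cc1OCCCCCCC(=O)NO`) gives 2300 nM and has the highest number of the three measured compounds, beyond the scatter from each of the other two. In this assay compound 2 (`COc1cc2c(Oc3ccc(NC(=O)c4nn(-c5ccccc5F)cc(C)c4=O)cc3F)ccnc2cc1OCCCCCC(=O)NO`) gives 590 nM and compound 3 (`COc1cc2c(Oc3ccc(NC(=O)c4nn(-c5ccccc5C)ccc4=O)cc3)ccnc2cc1OCCCCCC(=O)NO`) gives 700 nM and these two values lie within the scatter of each other. Going by the values given here, neither compound differs from compound 1 in one place only, so the measured set offers no single-change step to read across.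

Compound 4 (`COc1cc2c(Oc3ccc(NC(=O)c4nn(-c5ccccc5C)cc(C)c4=O)cc3)ccnc2cc1OCCCCCCC(=O)NO`) differs from compound 1 by one change (hydrogen in place of fluoro on an aromatic carbon) with hydrogen in place of fluoro on an aromatic carbon. Among the compounds with values here, with no measured step for this change, a modest move to a lower number in this assay is expected, possibly not beyond the scatter. The support is weak: compound 3, without fluoro on that ring, gives 700 nM but compound 2, with fluoro on that ring, gives 590 nM and both also differ from compound 1 elsewhere. The estimate is an expected 1.6-fold lower number from compound 1 to compound 4 (0.22 log units; within the scatter) and no more than that. For compound 4 the estimated value is 1400 nM with an expected range of 550 nM to 3000 nM until it is measured.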

Compound 4, half-maximal inhibitory concentration: 660 nM
For compound 4 the middle estimate is 2.1-fold (0.33 log units) above the measured one, within the range that was stated.
By their numbers in this assay, from the lowest: compounds 2, 4 and 3 (each within the scatter of the next); then compound 1.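

In this assay the series now has its first single-change step: hydrogen in place of fluoro on an aromatic carbon, ortho to a large group and meta to a large group, gives a 3.5-fold lower number from compound 1 to compound 4 (0.54 log units; beyond the scatter). The earlier compounds shown here differed from compound 1 in more than one place and could not separate this position from the other changes, whereas this pair shows that the fluoro-to-hydrogen change alone moves the number beyond the scatter. The reading rests on this one pair, and nothing given here bears on why the number moves.

The compounds shown leave open whether the size and direction of this step are specific to fluoro or would also appear with a chloro, methyl, methoxy or amine group at this place. They also leave open whether the same change gives a comparable step when the rest of the molecule differs, for example on a longer chain or with another group on the outer aromatic ring.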